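Swapping benzyl for pyrimidinyl on a sulfonamide nitrogen

The compounds below may be only part of what the source reports. "The series", "measured", "known", "first", "only" and "open" are said of these compounds alone.

Compound 1 `O=C(Nc1cccc(S(=O)(=O)Nc2ccccc2)c1)c1ccc(Cl)cc1Cl`: > 100000 nM
Compound 2 `O=C(Nc1ccc(S(=O)(=O)NCc2ccccc2)cc1)c1ccc(Cl)cc1Cl`: > 100000 nM
Compound 3 `N#Cc1ccc(C(=O)Nc2ccc(S(=O)(=O)Nc3ccccc3)cc2)c(F)c1`: 229 nM

Of the compounds shown here, three have been tested in a functional assay on HEK293 cells for agonist activity at probable G-protein coupled receptor 27 (Homo sapiens), read by a luciferase reporter and beta-arrestin recruitment, with a stated time of 10 min; a lower number here means that less compound is needed, a higher number that more compound is needed for the effect. For compound 1 the result is only a limit of the assay, > 100000 nM. For compound 2 the result is likewise only a limit, > 100000 nM. Among the measured compounds shown here, compound 3 is the one member of the group with a measured number, giving 229 nM in this assay. So compound 2 stands at the limit of > 100000 nM in this assay, at which 2 of the 3 values shown sit, and no step between measured compounds can be given.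

Compound 4 `O=C(Nc1ccc(S(=O)(=O)Nc2ncccn2)cc1)c1ccc(Cl)cc1Cl` is not yet measured. It differs from compound 2 in one place: pyrimidin-2-yl in place of benzyl on a sulfonamide nitrogen. Compound 3, the only active one, also carries a six-membered aromatic ring on its sulfonamide nitrogen, but it differs from compound 4 elsewhere as well, so it gives only a weak hint. Going by these compounds, with compound 2 sitting at a limit, the direction of any step is toward a smaller number; its size is unknown, and a further limit remains the single most likely outcome.

Compound 4 is expected to give about 30000 nM, somewhere between 2000 nM and 150000 nM. That estimate corresponds to an expected step of an at least 3.3-fold lower number from compound 2 to compound 4 (0.52 log units; beyond the scatter) in this assay.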

Compound 4, half-maximal effective concentration: > 100000 nM
Compound 4: a limit, no number; the forecaster's own chance of this, stated with the estimate: 55%; middle value at least 3.3-fold (0.52 log units) from the limit.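

In this assay compound 4 gives > 100000 nM, a limit of the assay and not a number. Among the compounds shown here, compound 2 gives > 100000 nM, also only a limit, so no step between compound 2 and compound 4 can be read. Compound 2 stays where it stood: the limit of > 100000 nM in this assay, at which 3 of the 4 values shown sit.

Going by these compounds, whether pyrimidin-2-yl in place of benzyl on a sulfonamide nitrogen changes the needed concentration at all remains open.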